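Replacing a Carboxyethyl Amide with a Dimethylamide

The source may report more compounds than this note shows. Statements on the series, on what has been measured and on what is new or still open speak of the compounds shown alone.

Three compounds have been measured in an assay on a protein complex for inhibition of CDK8/Cyclin C (Homo sapiens), with a stated time of 1 h; a lower number here means a stronger inhibitor, a higher number a weaker inhibitor:
Compound 1, `COC(=O)/C=C/c1ccncc1-c1ccc2ccccc2c1`: 40.6 nM
Compound 2, `O=C(/C=C/c1ccncc1-c1ccc2ccccc2c1)NC1CC1`: 40.1 nM
Compound 3, `O=C(O)CCNC(=O)/C=C/c1ccncc1-c1ccc2ccccc2c1`: 870 nM

Compound 3 stands highest of the three, shown by a 21-fold higher number from compound 1 to compound 3 (1.33 log units; beyond the scatter). Compound 4, `CN(C)C(=O)/C=C/c1ccncc1-c1ccc2ccccc2c1`, differs from compound 3 in one place: dimethylamino in place of (2-carboxyethyl)amino on a carbonyl carbon. The most relevant measured step is the one that put the 2-carboxyethyl in: there was a 22-fold higher number from compound 2 to compound 3 (1.34 log units; beyond the scatter). Taking it out again, this time for a dimethylamino, is expected to undo most of that loss, landing near the ester of compound 1 and the cyclopropylamide of compound 2. Compound 4 is therefore expected to show a 15-fold lower number from compound 3 to compound 4 (1.16 log units; beyond the scatter). Compound 4 is estimated at 60 nM, likely between 20 nM and 200 nM.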

Compound 4, half-maximal inhibitory concentration: 30.1 nM
Compound 4: middle estimate off by 2.0-fold (0.30 log units), on the high side, and the stated range covers the measured number.
By their numbers in this assay, from the lowest: compounds 4, 2 and 1 (each within the scatter of the next); then compound 3.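

In this assay, dimethylamino on this carbonyl carbon gives a large change from (2-carboxyethyl)amino (a 29-fold lower number from compound 3 to compound 4 (1.46 log units; beyond the scatter)), yet it stays level with cyclopropylamino (a 1.3-fold lower number from compound 2 to compound 4 (0.12 log units; within the scatter)) and with methoxy (a 1.3-fold lower number from compound 1 to compound 4 (0.13 log units; within the scatter)). The position therefore tolerates an amide with no amide hydrogen as well as one that has it, and of these four groups only (2-carboxyethyl)amino stands apart. Nothing available here explains that loss. Still open, going by these compounds, is whether the loss follows the carboxylic acid or the chain itself. A plain propyl chain on the amide nitrogen, or the same chain ending in an amine, would help separate the two.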